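The source may hold more compounds than are shown below. What is called first, only, known or untested is meant among the compounds shown, and "the series" means these compounds.

Working notes on the series built on the shared core of compound 1 `O=S(=O)(c1ccc(F)c(Cl)c1)c1cnc2cc(F)ccc2c1-c1cccc(F)c1`. Going by the values given here, in an ADME assay on microsomes from liver (Homo sapiens) for metabolic stability, tested at 2.5 uM (a higher number here means faster removal of the compound, a lower number slower removal), compound 1 gives 0.25 mL/min, the lowest of the three numbers measured so far. Compound 2 `O=S(=O)(c1ccc(F)c(Cl)c1)c1cnc2cc(F)ccc2c1-c1ccc(Cl)cc1` gives 0.39 mL/min, and compound 3 `O=S(=O)(c1ccc(F)c(Cl)c1)c1cnc2cc(F)ccc2c1-c1ccccc1F` gives 1.07 mL/min. The three measured steps all exchange the aryl group on the aromatic carbon of the core: a 1.6-fold higher number from compound 1 to compound 2 (0.19 log units; within the scatter); a 4.3-fold higher number from compound 1 to compound 3 (0.63 log units; beyond the scatter); a 2.7-fold higher number from compound 2 to compound 3 (0.44 log units; beyond the scatter). The last two are beyond the scatter, the first is not.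

Compound 4 `COc1ccc(S(=O)(=O)c2cnc3cc(F)ccc3c2-c2cccc(F)c2)cc1` has not yet been measured. Its difference from compound 1 lies elsewhere: 4-methoxyphenyl in place of 3-chloro-4-fluorophenyl on a sulfonyl sulfur. Among the compounds with values here, none of the measured steps changes the group on the sulfonyl sulfur; every one of them varies the other aryl group, so no measured step bears directly on this change. What the measured steps do show is that a single aryl swap on this core can move the number by a modest amount in either position of the spread, and they give no direction for the sulfonyl side. The expected step is therefore set as a 2.0-fold higher number from compound 1 to compound 4 (0.30 log units; within the scatter), a shift around the size of the within-scatter steps, with a wide range to allow for the absence of a comparable measurement. Compound 4 is estimated at 0.5 mL/min, with a range from 0.2 mL/min to 1.3 mL/min.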

Compound 4, intrinsic clearance in a liver preparation (reported as CLH), per the amount of preparation that the assay uses: 2.94 mL/min
For compound 4 the middle estimate is 5.9-fold (0.77 log units) below the measured one, outside the stated range (above it).
By their numbers in this assay, from the lowest: compounds 1 and 2 (each within the scatter of the next); then compound 3; then compound 4.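

In this assay the group on the sulfonyl sulfur turns out to matter more than the measured exchanges of the other aryl group suggested: 4-methoxyphenyl in place of 3-chloro-4-fluorophenyl gives a 12-fold higher number from compound 1 to compound 4 (1.07 log units; beyond the scatter) and so exceeds the largest of those exchanges, which is a 4.3-fold higher number from compound 1 to compound 3 (0.63 log units; beyond the scatter) in this series. Going by these compounds alone, this is the first step at this position, and it shows that the low number of compound 1 does not survive this change even with the 3-fluorophenyl group and the rest of the shared core held constant. The six-membered aromatic ring of carbon and the heavy-atom count stay the same across the change, while two halogens leave and a methoxy group enters.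

The compounds shown do not separate the loss of the chlorine and fluorine from the arrival of the methoxy group, and a plain phenyl, a 4-hydroxyphenyl or an aryl group carrying an amine on the sulfonyl sulfur would bear on that question. No measurement at hand gives a reason for the size of this step.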